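A few compounds are considered here, and "the series" means these few. Any claim that something is new, unique, unknown or untested is made for them only; others in the source may bear on it.

Measured compounds in an assay on isolated protein for inhibition of Amine oxidase [flavin-containing] B (Homo sapiens), read by fluorescence; a higher number here means a weaker inhibitor, a lower number a stronger inhibitor:
- compound 1 `Cn1c(=O)c2c(nc(Sc3ccccc3)n2C)n(C)c1=O` gives 33200 nM
- compound 2 `Cn1c(=O)c2c(nc(SCc3ccccc3)n2C)n(C)c1=O` gives 1860 nM
- compound 3 `CC(C)CCSc1nc2c(c(=O)n(C)c(=O)n2C)n1C` gives 2620 nM

Compound 3 stands second highest of the three numbers; its value and that of compound 2 lie within the scatter of each other, while compound 1 sits far apart: a 13-fold lower number from compound 1 to compound 3 (1.10 log units; beyond the scatter). Compound 4 `Cn1c(=O)c2c(nc(SC3CCCCC3)n2C)n(C)c1=O` differs from compound 3 by cyclohexyl in place of isopentyl on a sulfur. Going by the values given here, the steps that bear on this both replace phenyl on the sulfur with a saturated group and are large: an 18-fold lower number from compound 1 to compound 2 (1.25 log units; beyond the scatter) and a 13-fold lower number from compound 1 to compound 3 (1.10 log units; beyond the scatter). The step between two saturated groups is within the scatter: a 1.4-fold higher number from compound 2 to compound 3 (0.15 log units; within the scatter). Compound 4 keeps a saturated group on the sulfur, so no step beyond the scatter is expected in this assay. Compound 4 is estimated at 2500 nM, range 900 nM to 7000 nM, an expected step of a 1.0-fold lower number from compound 3 to compound 4 (0.02 log units; within the scatter).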

Compound 4, half-maximal inhibitory concentration: 13100 nM
Estimate against measurement, compound 4: 5.2-fold (0.72 log units) below; measured number above the stated range.
By their numbers in this assay, from the lowest: compounds 2 and 3 (each within the scatter of the next); then compound 4; then compound 1.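

Going from phenyl to another group on the sulfur does not give one uniform gain in this assay: cyclohexyl keeps only part of it, with a 2.5-fold lower number from compound 1 to compound 4 (0.40 log units; beyond the scatter). The same group gives up ground against both the open chain and benzyl, with a 5.0-fold higher number from compound 3 to compound 4 (0.70 log units; beyond the scatter) and a 7.0-fold higher number from compound 2 to compound 4 (0.85 log units; beyond the scatter). Going by these compounds alone, the position therefore separates cyclohexyl from isopentyl, a difference the earlier compounds did not show.

As far as these compounds go, whether cyclopentyl or a longer chain carrying an amine would sit nearer cyclohexyl or isopentyl stays open. Nothing at hand accounts for the gap between the ring and the open chain.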